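The compounds below may be only part of what the source reports. "The series", "measured", "known", "first", "only" and "open" are said of these compounds alone.

Measured so far:
- compound 1, `CC(C)Oc1cccc(-c2csc(NC(=O)c3ccc([N+](=O)[O-])o3)n2)c1`: in an ADME assay on Vero cells (Chlorocebus sabaeus) for cytotoxicity, read by MTT assay, with a stated time of 72 h (a higher number here means a weaker inhibitor, a lower number a stronger inhibitor), compound 1 gives 69500 nM
- compound 2, `O=C(Nc1nc(-c2cccc(NC(=O)C3CCC3)c2)cs1)c1ccc([N+](=O)[O-])o1`: in this assay compound 2 stands at "not determined" (no result reported)

Compound 2 therefore has no number of its own in this assay; only compound 1 anchors the series, and it sits at the weak end. Compound 3, `CS(=O)(=O)Nc1cccc(-c2csc(NC(=O)c3ccc([N+](=O)[O-])o3)n2)c1`, differs from compound 2 by methylsulfonyl in place of cyclobutylcarbonyl on a nitrogen on an aromatic ring. For the measured compounds named here, no step between measured compounds covers this change, so the size of its effect in this assay is open; nothing here argues for a shift beyond the scatter in either direction. Compound 3 is expected near 65000 nM, estimated between 20000 nM and 200000 nM.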

Compound 3, half-maximal inhibitory concentration: < 2820 nM
Compound 3: no number, only a limit; the forecaster's own chance of this, stated with the estimate: 35%; at least 23-fold (1.36 log units) between middle value and limit.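

Compound 3 carries a limit, not a number: the limit of < 2820 nM in this assay, at which 1 of the 3 values shown sits. Even so, methanesulfonamido in place of isopropoxy on an aromatic carbon gives an at least 24-fold lower number from compound 1 to compound 3 (1.39 log units; beyond the scatter), which shows that this assay responds to the group at this place. Nothing shown bears on the cause of this step.

The change from cyclobutylcarbonyl to methylsulfonyl on the nitrogen cannot be read, as compound 2 has no number. Also open, from the compounds shown here alone, is whether a free amine or a carboxylic acid on this aromatic carbon would give a similarly low number.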